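Phenyl to 4-methylphenyl in the series

The source may hold more compounds than are shown below. What is called first, only, known or untested is meant among the compounds shown, and "the series" means these compounds.

In an ADME assay on H9c2 cells (Rattus norvegicus) for cytotoxicity, read by MTT assay, with a stated time of 48 h (on this read-out higher numbers stand for weaker inhibition and lower numbers for stronger inhibition), compound 2 (`O=C(NCCOC(=S)Nc1ccccc1)c1cccnc1`) gives > 800000 nM as a limit, not a number. Compound 1 (`O=C(NCCOC(=S)Nc1ccc(F)cc1)c1cccnc1`) gives > 800000 nM, also a limit. Compound 3 (`CC(C)(Oc1ccc(Cl)cc1)C(=O)NCCOC(=S)Nc1ccc([N+](=O)[O-])cc1Cl`) gives > 800000 nM, again a limit. All three therefore sit at one reading (the limit of > 800000 nM in this assay, at which 3 of the 3 values shown sit), and compound 2 has no exact standing. Compound 4 (`Cc1ccc(NC(=S)OCCNC(=O)c2cccnc2)cc1`) carries methyl in place of hydrogen on an aromatic carbon, para to a large group (methyl in place of hydrogen on an aromatic carbon). Among the compounds with values here, the only measured step (a step that the two limits leave unreadable from compound 1 to compound 2) offers no size to carry over. The expected step (a number no higher from compound 2 to compound 4 (the limit leaves the size open)) stays within the scatter in this assay, with no direction favoured. Compound 4 is estimated at 800000 nM with an expected range from 400000 nM to 1600000 nM and a report as a limit the likeliest outcome.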

Compound 4, half-maximal inhibitory concentration: 726000 nM
For compound 4 the middle estimate is 1.1-fold (0.04 log units) above the measured one, within the range that was stated.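

Within the data shown here, compound 4 is the first compound to give an exact number rather than a limit, so the 4-methylphenyl change makes this position readable for the first time. Methyl in place of hydrogen gives an at least 1.1-fold lower number from compound 2 to compound 4 (0.04 log units; that floor lies within the scatter), and methyl in place of fluoro gives an at least 1.1-fold lower number from compound 1 to compound 4 (0.04 log units; that floor lies within the scatter), so only a floor is known for each step. Most of the set still reads as a limit: the limit of > 800000 nM in this assay, at which 3 of the 4 values shown sit.

As far as these compounds go, the true size of both steps remains open. Also open, from the compounds shown here alone, is whether an amine, a carboxylic acid or a longer chain in place of the methyl gives a step beyond the scatter.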